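The source may hold more compounds than are shown below. What is called first, only, known or untested is meant among the compounds shown, and "the series" means these compounds.

Compound 1 `CCC(CC)n1c(-c2ccc(OCc3c(-c4c(Cl)cccc4Cl)noc3C(C)C)cc2)nc2ccc(C(=O)O)cc21` gives 0.8 nM in an assay on Huh-7 cells for agonist activity at Bile acid receptor (Homo sapiens), read by a luciferase reporter; on this read-out lower numbers stand for an effect already at smaller amounts and higher numbers for an effect only at larger amounts of compound.
Compound 2 `CC(C)c1onc(-c2c(Cl)cccc2Cl)c1COc1ccc(-c2nc3ccc(C(=O)O)cc3n2C)c(Cl)c1` gives 3.66 nM in this assay.
Compound 3 `CC(C)c1onc(-c2c(Cl)cccc2Cl)c1COc1ccc(-c2nc3ccc(C(=O)O)cc3n2CC2CCCCC2)c(Cl)c1` gives 7.6 nM in this assay.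

Compound 3 has the highest number of the three, so it needs the largest amount for a half-maximal effect; compound 2 lies one step below it, and compound 1 lies furthest away. Compound 4 `CCC(CC)n1c(-c2ccc(OCc3c(-c4c(Cl)cccc4Cl)noc3C(C)C)cc2Cl)nc2ccc(C(=O)O)cc21` has not yet been measured. It differs from compound 3 in one place: pentan-3-yl in place of cyclohexylmethyl on an aromatic nitrogen. Going by the values given here, only one measured step touches that same ring nitrogen: a 2.1-fold higher number from compound 2 to compound 3 (0.32 log units; beyond the scatter), where a ring was added onto the group at that nitrogen and the number rose modestly. Compound 4 goes the other way, losing the ring and taking a branched chain instead, so a modest fall is the natural expectation. Compound 1 carries the same pentan-3-yl group, though its structure differs elsewhere, and reaches a low number. On that footing compound 4 is expected to show a 3.8-fold lower number from compound 3 to compound 4 (0.58 log units; beyond the scatter) in this assay. The estimate for compound 4 is 2 nM, with a range from 0.6 nM to 6 nM.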

Compound 4, half-maximal effective concentration: 1.6 nM
The estimate for compound 4 lay 1.3-fold (0.10 log units) above the measured number; measured number inside the range.
By their numbers in this assay, from the lowest: compounds 1 and 4 (each within the scatter of the next); then compound 2; then compound 3.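

Measured in this assay, putting pentan-3-yl on the aromatic nitrogen in place of cyclohexylmethyl gives a 4.8-fold lower number from compound 3 to compound 4 (0.68 log units; beyond the scatter) and putting it there in place of methyl gives a 2.3-fold lower number from compound 2 to compound 4 (0.36 log units; beyond the scatter). Among these three groups, then, the number does not climb steadily as the group grows from methyl through pentan-3-yl to cyclohexylmethyl: the branched chain gives the lowest number of the three. With pentan-3-yl on that nitrogen, chloro in place of hydrogen on an aromatic carbon gives a 2.0-fold higher number from compound 1 to compound 4 (0.30 log units; within the scatter), so this swap cannot be told apart from the noise of repeat measurements.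

As far as these compounds go, whether isopropyl or a straight pentyl chain on the same nitrogen would give a similarly low number remains open. Nothing available explains why pentan-3-yl gives the lowest number of the three.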